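Removing a Methoxy Group: Expected Cytotoxicity of Compound 4

This account rests on a few compounds, and the source may have more. Where it says the series, first, only, none or still open, it means among the compounds named here.

Compound 3 `COc1ccc(-c2nc3c(C(=O)Nc4nc5ccccc5[nH]4)cccc3[nH]2)c(OC)c1OC` gives 29 uM in an ADME assay on Vero cells (Chlorocebus sabaeus) for cytotoxicity (on this read-out lower numbers stand for higher toxicity in this test and higher numbers for lower toxicity in this test), the second highest of the three numbers available. Compound 2 `COc1ccc(-c2nc3c(C(=O)NCCCO)cccc3[nH]2)c(OC)c1OC` gives 40 uM, and the step of a 1.4-fold lower number from compound 2 to compound 3 (0.14 log units; within the scatter) lies within the scatter. Compound 1 `CCC(CC)NC(=O)c1cccc2[nH]c(-c3ccc(OC)c(OC)c3)nc12` gives 2.23 uM, a much lower number than compound 3. Compound 4 `COc1ccc(-c2nc3c(C(=O)Nc4nc5ccccc5[nH]4)cccc3[nH]2)cc1OC` differs from compound 3 by hydrogen in place of methoxy on an aromatic carbon. No measured step concerns this change; the only step shown, a 1.4-fold lower number from compound 2 to compound 3 (0.14 log units; within the scatter), altered the amide substituent and stayed within the scatter. Compound 1 also lacks this methoxy group, yet its amide substituent differs as well, so its value cannot be read as this step alone. Compound 4 is therefore expected to stay within the scatter of compound 3, a 1.2-fold lower number from compound 3 to compound 4 (0.06 log units; within the scatter). The estimate for compound 4 is 25 uM, in a range of 8 uM to 70 uM.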

Compound 4, half-maximal toxic concentration: 51.8 uM
Compound 4: middle estimate off by 2.1-fold (0.32 log units), on the low side; the measured number falls inside the stated range.
By their numbers in this assay, from the lowest: compound 1; then compounds 3, 2 and 4 (each within the scatter of the next).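

In this assay, for the compounds shown here, the step of a 1.8-fold higher number from compound 3 to compound 4 (0.25 log units; within the scatter) gives the first direct reading of hydrogen in place of methoxy at this position, ortho to a large group, and it lies within the scatter. With this methoxy absent from both compounds, the amide substituent alone accounts for the large step of a 23-fold higher number from compound 1 to compound 4 (1.37 log units; beyond the scatter), with 1H-benzimidazol-2-yl in place of pentan-3-yl. No measurement is at hand that explains either step. As far as these compounds go, whether an amine or an ethoxy group at this position would also stay within the scatter remains open, as does the same removal alongside the 3-hydroxypropyl amide of compound 2.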